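Amide variation across three measured compounds and one untested analogue

The compounds below may be only part of what the source reports. "The series", "measured", "known", "first", "only" and "open" are said of these compounds alone.

Measured compounds and values in a functional assay on MGC-803 cells (Homo sapiens) for inhibition, read by CCK-8 assay, with a stated time of 72 h; a lower number here means a stronger inhibitor, a higher number a weaker inhibitor:
- compound 1 `CC(C)(C)OC(=O)N1CCN(C(=O)Cn2cc(CN3C(=O)C(=O)c4c(Cl)ccc(Cl)c43)nn2)CC1` gives 22000 nM
- compound 2 `O=C1C(=O)N(Cc2cn(CC(=O)N3CCOCC3)nn2)c2c(Cl)ccc(Cl)c21` gives 51700 nM
- compound 3 `O=C(Cn1cc(CN2C(=O)C(=O)c3c(Cl)ccc(Cl)c32)nn1)NC1CCCCC1` gives 17400 nM

Compound 3 holds the lowest of the three numbers. Compound 1 sits close to it, within the scatter, so no order between compound 3 and compound 1 can be read from these numbers. For the measured compounds named here, compound 2 is the furthest away; the only single-point step in the set is a 3.0-fold lower number from compound 2 to compound 3 (0.47 log units; beyond the scatter), a modest change on the carbonyl carbon of the amide.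

Compound 4 `O=C(Cn1cc(CN2C(=O)C(=O)c3c(Cl)ccc(Cl)c32)nn1)Nc1ccccc1` is the next member. It differs from compound 3 by phenyl in place of cyclohexyl on an amide-type nitrogen. Going by the values given here, no measured step bears on this exchange: the one step available swaps the amine attached to the carbonyl rather than replacing one six-membered carbon ring with another on the amide nitrogen. With nothing to anchor a direction, the expected step for compound 4 is none beyond the scatter, a 1.1-fold lower number from compound 3 to compound 4 (0.04 log units; within the scatter). Compound 4 is therefore estimated at 16000 nM, with a range from 6000 nM to 45000 nM.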

Compound 4, half-maximal inhibitory concentration: 17500 nM
Beside the measured number, compound 4's estimate is 1.1-fold (0.04 log units) below it, within the range that was stated.
By their numbers in this assay, from the lowest: compounds 3, 4 and 1 (each within the scatter of the next); then compound 2.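

On the amide-type nitrogen, in this assay, phenyl in place of cyclohexyl gives a 1.0-fold higher number from compound 3 to compound 4 (0.00 log units; within the scatter), so the aromatic and the non-aromatic six-membered carbon ring cannot be told apart at this place. Anilino in place of morpholin-4-yl gives a 3.0-fold lower number from compound 2 to compound 4 (0.47 log units; beyond the scatter), matching a 3.0-fold lower number from compound 2 to compound 3 (0.47 log units; beyond the scatter), which means the lower number relative to compound 2 holds with either carbon ring on the nitrogen. No available data offer an explanation for these steps.

Still open, as far as these compounds go, is how a methyl group, a benzyl group or a phenyl ring carrying a methoxy group on the same nitrogen would read. The shared core stays constant in all the compounds shown, leaving open what fluorine or hydrogen in place of its chlorines would do.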